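A Dihydroxyphenyl Replaces the Methylphenyl Group

The source may report more compounds than this note shows. Statements on the series, on what has been measured and on what is new or still open speak of the compounds shown alone.

Compound 3 `COc1cc(-n2c(-c3ccc(C)cc3)csc2=S)cc(OC)c1OC` holds the lowest of the two numbers in a functional assay on MCF7 cells (Homo sapiens) for cytotoxicity, read by MTT assay, with a stated time of 48 h (on this read-out lower numbers stand for stronger inhibition and higher numbers for weaker inhibition), where compound 3 gives 19.7 ug/mL. Its nearest neighbour is compound 1 `COc1cc(-n2c(-c3ccc(F)cc3)csc2=S)cc(OC)c1OC`, which in this assay gives 38.5 ug/mL; the step of a 2.0-fold lower number from compound 1 to compound 3 (0.29 log units; within the scatter) stays within the scatter. Compound 2 `COc1cc(-n2c(-c3ccc(Cl)cc3)csc2=S)cc(OC)c1OC` reaches only a limit of the assay in this assay, where compound 2 gives > 100 ug/mL.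

Compound 4 `COc1cc(-n2c(-c3ccc(O)c(O)c3)csc2=S)cc(OC)c1OC` differs from compound 3 by 3,4-dihydroxyphenyl in place of 4-methylphenyl on an aromatic carbon. The measured steps touch the same aromatic carbon but exchange only halogen for methyl: an at least 5.0-fold lower number from compound 2 to compound 3 (0.70 log units; beyond the scatter) and a 2.0-fold lower number from compound 1 to compound 3 (0.29 log units; within the scatter). Going by the values given here, no measured step introduces hydroxyl groups, so the direction is open. Compound 4 is expected to give 35 ug/mL, within 10 ug/mL to 100 ug/mL, a step of a 1.8-fold higher number from compound 3 to compound 4 (0.25 log units; within the scatter) that is estimated, not measured.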

Compound 4, half-maximal inhibitory concentration: > 100 ug/mL
Compound 4: only a limit was reported; the forecaster's own chance of this, stated with the estimate: 25%; at least 2.8-fold (0.45 log units) between middle value and limit.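

At this aromatic carbon, the only change shown that brings in hydroxyl groups moves the read-out in this assay beyond the scatter in both readable steps: an at least 5.0-fold higher number from compound 3 to compound 4 (0.70 log units; beyond the scatter) and an at least 2.5-fold higher number from compound 1 to compound 4 (0.41 log units; beyond the scatter). Compound 4 is a limit of the assay, and it shares that limit with compound 2: the limit of > 100 ug/mL in this assay, at which 2 of the 4 values shown sit. The step from compound 2 to compound 4 cannot be read.

The compounds shown leave open how a phenyl bearing a single hydroxyl would read at this carbon. They also leave open how an amine or a carboxylic acid would read there.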